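Clearance notes: from compound 3 to compound 4

The source may report more compounds than this note shows. Statements on the series, on what has been measured and on what is new or still open speak of the compounds shown alone.

Measured in an ADME assay on microsomes from liver (Homo sapiens) for metabolic stability, read by LC-MS, using NADPH, with stated times of 5 min and 30 min, tested at 1 uM; on this read-out higher numbers stand for fast clearance and lower numbers for slow clearance:
- compound 1 `O=C1c2ccccc2CN1c1cnc(NCc2c(F)ccc3c2CCO3)n2cnnc12`: 13 mL.min-1.g-1
- compound 2 `C[C@@H]1CC(=O)N(c2cnc(NCc3c(F)ccc4c3CCO4)n3cnnc23)C1`: < 3 mL.min-1.g-1 (a limit)
- compound 3 `CN(C(=O)c1ccccc1)c1cnc(NCc2c(F)ccc3c2CCO3)n2cnnc12`: > 300 mL.min-1.g-1 (a limit)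

Compound 3 gives > 300 mL.min-1.g-1, a limit of the assay and the highest of the three readings. Compound 4 `C[C@H]1CC(=O)N(c2cnc(NCc3c(F)ccc4c3CCO4)n3cnnc23)C1` carries 4-methyl-2-oxopyrrolidin-1-yl in place of benzoyl(methyl)amino on an aromatic carbon. The closest measured step is an at least 100-fold higher number from compound 2 to compound 3 (2.00 log units; beyond the scatter), large and beyond the scatter, and it removes the group that enters here. The step of an at least 23-fold higher number from compound 1 to compound 3 (1.36 log units; beyond the scatter) is also large, while an at least 4.3-fold lower number from compound 1 to compound 2 (0.63 log units; beyond the scatter) is modest. Running the closest step in reverse, a large fall in this assay is expected, and the estimated step is an at least 75-fold lower number from compound 3 to compound 4 (1.87 log units; beyond the scatter). The estimated value for compound 4 is 4 mL.min-1.g-1, with an expected range from 2 mL.min-1.g-1 to 15 mL.min-1.g-1.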

Compound 4, intrinsic clearance in microsomes: < 3 mL.min-1.g-1
Compound 4 was reported as a limit; the forecaster's own chance of this, stated with the estimate: 45%; at least 1.3-fold (0.12 log units) between middle value and limit.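

Placing 4-methyl-2-oxopyrrolidin-1-yl on this aromatic carbon in place of benzoyl(methyl)amino gives an at least 100-fold lower number from compound 3 to compound 4 (2.00 log units; beyond the scatter), and the comparison with the core of compound 1 gives an at least 4.3-fold lower number from compound 1 to compound 4 (0.63 log units; beyond the scatter); both sizes rest on limits. The drawn configuration is the only change between compound 2 and compound 4: the fact that compounds 2 and 4 differ only in the configuration as drawn Neither configuration comes off the low limit, so the step between them cannot be read: the limit of < 3 mL.min-1.g-1 in this assay, at which 2 of the 4 values shown sit.

On these data alone, how far the true clearance of compound 2 and compound 4 lies past that limit stays open. Also open, as far as these compounds go, is whether an amine or a longer chain in place of the methyl would keep the reading there.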